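Replacing a Pyrazolyl Ring with Ethyl: Expected Binding Shift

This account rests on a few compounds, and the source may have more. Where it says the series, first, only, none or still open, it means among the compounds named here.

Measured compounds:
compound 1, `CN1CCN(CCCS(=O)(=O)c2ccc3nc(NC(=O)NC(=O)c4cccc(-n5cccn5)c4Cl)sc3c2)CC1`: 8.8 nM
compound 2, `CN1CCN(CCCS(=O)(=O)c2ccc3nc(NC(=O)NC(=O)c4cc(-n5cccn5)c(Cl)cc4Cl)sc3c2)CC1`: 0.31 nM

In an assay on HEK293 cells for displacement of a labelled ligand from growth hormone secretagogue receptor type 1 (Homo sapiens), with a stated time of 60 min (a lower number here means a stronger inhibitor, a higher number a weaker inhibitor), compound 1 gives 8.8 nM, the higher of the two numbers shown. Compound 2 gives 0.31 nM, and the gap between them lies beyond the scatter. Compound 3, `CCc1ccc(Cl)c(C(=O)NC(=O)Nc2nc3ccc(S(=O)(=O)CCCN4CCN(C)CC4)cc3s2)c1`, has not been measured. It differs from compound 1 in one place: 2-chloro-5-ethylphenyl in place of 2-chloro-3-(1H-pyrazol-1-yl)phenyl on a carbonyl carbon. Going by the values given here, no measured pair shows this exact change, so the expectation rests on the change alone. A modest move towards weaker binding is expected, with a wide range. Compound 3 is estimated at 20 nM, between 4 nM and 100 nM. The step of a 2.3-fold higher number from compound 1 to compound 3 (0.36 log units; beyond the scatter) is thus expected to be small.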

Compound 3, half-maximal inhibitory concentration: 0.078 nM
Beside the measured number, compound 3's estimate is 260-fold (2.41 log units) above it; measured number below the stated range.
By their numbers in this assay, from the lowest: compound 3; then compound 2; then compound 1.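

In this assay, putting 2-chloro-5-ethylphenyl in place of 2-chloro-3-(1H-pyrazol-1-yl)phenyl on a carbonyl carbon gives a 110-fold lower number from compound 1 to compound 3 (2.05 log units; beyond the scatter) in a single change. This group on the carbonyl carbon therefore has a large effect on the number, and strong binding in this series does not require the pyrazolyl ring. Nothing available explains the size of this step.

The compounds shown cannot separate the loss of the pyrazolyl ring from the gain of the ethyl group. On these data alone, whether a methyl, propyl or methoxy group would match ethyl remains open.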